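This account rests on a few compounds, and the source may have more. Where it says the series, first, only, none or still open, it means among the compounds named here.

Two members of this series carry a full number. In a functional assay on A549 cells (Homo sapiens) for antiproliferative activity, read by MTT assay, with a stated time of 72 h (a lower number here means a stronger inhibitor, a higher number a weaker inhibitor), compound 1 `COc1cc2ncnc(Nc3ccc(OCc4cccc(F)c4)c(Cl)c3)c2cc1OCCCN1CCNCCNCCNCC1` gives 3400 nM, and compound 2 `COc1cc2ncnc(Nc3ccc(Cl)c(C(F)(F)F)c3)c2cc1OCCCN1CCNCCNCCNCC1` gives 5350 nM. Compound 3 `C#Cc1cccc(Nc2ncnc3cc(OC)c(OCCCN4CCNCCNCC4)cc23)c1` stands differently: in this assay it returns only a limit, > 50000 nM, not a number. That places compound 3 at the assay limit (the limit of > 50000 nM in this assay, at which 1 of the 3 values shown sits), and it is the only one of the three to sit there, so its true potency is known only to lie beyond the weakest point the assay can report.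

Compound 4 `COc1cc2ncnc(Nc3cccc(I)c3)c2cc1OCCCN1CCNCCNCC1` has not yet been measured in this assay. It departs from compound 3 in a single place: iodo in place of ethynyl on an aromatic carbon. Everything else, including the shared core of compound 3, is kept.

Within the data shown here, no measured pair of compounds isolates this change, so the expectation rests on the limit of compound 3 alone. With an ethynyl giving way to an iodo on the same aromatic carbon, the step from compound 3 to compound 4 is expected to be an at least 1.1-fold lower number from compound 3 to compound 4 (0.04 log units; that floor lies within the scatter), that is, no movement beyond the scatter, and compound 4 is estimated at about 45000 nM, with a range from 12000 nM to 150000 nM.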

Compound 4, half-maximal inhibitory concentration: 26200 nM
For compound 4 the middle estimate is 1.7-fold (0.23 log units) above the measured one; measured number inside the range.
By their numbers in this assay, from the lowest: compounds 1 and 2 (each within the scatter of the next); then compound 4. At a limit, above all of these: compound 3.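

In this assay compound 4 shows that, with iodo on this aromatic carbon, the series can return a full number: compound 4 gives 26200 nM. Compound 3, with ethynyl in the same place, returns only a limit, > 50000 nM. The change therefore reads as an at least 1.9-fold lower number from compound 3 to compound 4 (0.28 log units; that floor lies within the scatter), which is a floor and not a size: the limit of > 50000 nM in this assay, at which 1 of the 4 values shown sits.

From the compounds shown here alone, whether the true step lies beyond the scatter remains open, as does how a smaller halogen such as bromo or chloro, or a nitrile, would read on this carbon in this assay. Going by these compounds, it also remains open whether the swap from ethynyl to iodo would give a similar step with the side chain carried by compound 1 and compound 2.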